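This account rests on a few compounds, and the source may have more. Where it says the series, first, only, none or still open, it means among the compounds named here.

For the measured compounds named here, in a functional assay on DWD cells (Homo sapiens) for inhibition, read by sulforhodamine B assay (a higher number here means a weaker inhibitor of growth, a lower number a stronger inhibitor of growth), compound 1 (`Cc1ccc2[nH]c(-c3ccc(-c4ccc(-c5ccc(N(C)C)cc5)cc4)cc3)nc2c1`) gives 3230 nM, the lowest of the three numbers measured so far. Compound 2 (`CN(C)c1ccc(-c2ccc(-c3ccc(-c4nc5ccccc5[nH]4)cc3)cc2)cc1`) gives 100000 nM, and compound 3 (`CN(C)c1ccc(-c2ccc(-c3ccc(-c4nc5c(O)cccc5[nH]4)cc3)cc2)cc1`) gives 9210 nM. Putting hydrogen in place of methyl produces a 31-fold higher number from compound 1 to compound 2 (1.49 log units; beyond the scatter), a large step. Putting hydroxy in place of hydrogen produces an 11-fold lower number from compound 2 to compound 3 (1.04 log units; beyond the scatter), also large. The remaining comparison, a 2.9-fold higher number from compound 1 to compound 3 (0.46 log units; beyond the scatter), is modest.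

Compound 4 (`Cc1ccc2[nH]c(-c3ccc(-c4ccc(-c5ccc(C(F)(F)F)cc5)cc4)cc3)nc2c1`) differs from compound 1 in one place: trifluoromethyl in place of dimethylamino on an aromatic carbon. This puts trifluoromethyl in place of dimethylamino on an aromatic carbon, para to a large group. Going by the values given here, all three measured compounds carry the dimethylamino group, so no measured step tests this change directly. The steps bear on it only indirectly, showing that single substitutions in this small set can move the number by a large amount. The data do not fix a direction. A modest step towards a higher number is expected, given that compound 1 already stands lowest at 3230 nM, but with wide uncertainty. The estimated step is a 1.9-fold higher number from compound 1 to compound 4 (0.27 log units; within the scatter). For compound 4 the estimated value is 6000 nM, with an expected range from 1500 nM to 25000 nM.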

Compound 4, concentration for 50% growth inhibition: 38200 nM
The estimate for compound 4 lay 6.4-fold (0.80 log units) below the measured number, and the stated range ends below it.
By their numbers in this assay, from the lowest: compound 1; then compound 3; then compound 4; then compound 2.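

In this assay, for the compounds shown here, the position para to a large group, which carried dimethylamino in all the earlier compounds, now proves sensitive to substitution: a 12-fold higher number from compound 1 to compound 4 (1.07 log units; beyond the scatter). A change at this site can therefore move the number by a large step, just as the changes on the benzimidazole side did between compound 1, compound 2 and compound 3. The direction is also now settled for this one pair, with dimethylamino giving the lower number and trifluoromethyl the higher, though the data shown contain no measurement that would account for this difference.

What the compounds leave open is whether dimethylamino itself matters or whether other groups at this place would serve as well, such as a primary amine, a methoxy group or a morpholine ring, and whether a group of intermediate size would give an intermediate number. Going by these compounds, it also remains open whether the same exchange would give a step of similar size and direction with the 4-hydroxy-1H-benzimidazol-2-yl group of compound 3, or with the unsubstituted partner found in compound 2.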